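The source may hold more compounds than are shown below. What is called first, only, known or untested is meant among the compounds shown, and "the series" means these compounds.

Values so far in a functional assay on Jurkat cells (Homo sapiens) for cytotoxicity, with a stated time of 48 h; on this read-out higher numbers stand for weaker inhibition and lower numbers for stronger inhibition:
- compound 1 (`CCOC(=O)CC1C(C(=O)OCC)=C(N)Oc2ccccc21`) gives 91400 nM 
- compound 2 (`CCOC(=O)CC1C(C(=O)OCC)=C(N)Oc2ccc(-c3ccc(C(C)(C)C)cc3)cc21`) gives 35500 nM 

Compound 1 holds the higher of the two numbers. Compound 3 (`CCOC(=O)CC1C(C(=O)OCC)=C(N)Oc2c(-c3ccccc3)cccc21`) is not yet measured and differs from it by phenyl in place of hydrogen on an aromatic carbon in the form of phenyl in place of hydrogen on an aromatic carbon, ortho to a fused ring and meta to a fused ring. Going by the values given here, one measured step bears on this: a 2.6-fold lower number from compound 1 to compound 2 (0.41 log units; beyond the scatter) for 4-(tert-butyl)phenyl in place of hydrogen on an aromatic carbon. A single step is a thin guide, so a smaller step in the same direction is expected in this assay and it may stay within the scatter. The expected change is a 1.7-fold lower number from compound 1 to compound 3 (0.22 log units; within the scatter) on this estimate. Compound 3 is estimated at 55000 nM (range 25000 nM to 110000 nM) for now.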

Compound 3, half-maximal inhibitory concentration: 49800 nM
For compound 3 the middle estimate is 1.1-fold (0.04 log units) above the measured one; measured number inside the range.
By their numbers in this assay, from the lowest: compounds 2, 3 and 1 (each within the scatter of the next, the first and the last beyond it).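

In this assay, phenyl in place of hydrogen on this aromatic carbon, ortho to a fused ring and meta to a fused ring, gives a 1.8-fold lower number from compound 1 to compound 3 (0.26 log units; within the scatter) on the core of compound 1. This carbon therefore takes the added six-membered aromatic ring, but the read-out does not separate the two compounds. Nothing measured here accounts for this result.

Still open, going by these compounds, is whether a smaller or differently built group here, such as an amine or a carboxylic acid, would give a step beyond the scatter. Also open, on these data alone, is whether 4-(tert-butyl)phenyl on this same carbon would do so.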